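The source may report more compounds than this note shows. Statements on the series, on what has been measured and on what is new or still open speak of the compounds shown alone.

Compound 2 `COc1cc2cc(Oc3ccc(NC(=O)Nc4ccc(Cl)c(C(F)(F)F)c4)cc3)c(C)nc2cc1OC` gives 2590 nM in a functional assay on COLO 205 cells (Homo sapiens) for inhibition, read by sulforhodamine B assay, with a stated time of 48 h (on this read-out lower numbers stand for higher toxicity in this test and higher numbers for lower toxicity in this test), the lowest of the two numbers available. Compound 1 `COc1cc2cc(Oc3ccc(NC(=O)Nc4cccc(C(F)(F)F)c4)cc3)c(C)nc2cc1OC` gives 5700 nM in this assay, and the step of a 2.2-fold lower number from compound 1 to compound 2 (0.34 log units; beyond the scatter) counts as modest. Compound 3 `COc1cc2cc(Oc3ccc(NC(=O)Nc4ccc(Cl)c(Cl)c4)cc3)c(C)nc2cc1OC` differs from compound 2 by chloro in place of trifluoromethyl on an aromatic carbon. Among the measured compounds shown here, no measured step swaps these two groups; the single step measured so far concerns a different position on the same ring. For compound 3 no change beyond the scatter is therefore expected in this assay, a step of a 1.4-fold higher number from compound 2 to compound 3 (0.13 log units; within the scatter), giving an estimated 3500 nM within a range from 1200 nM to 10000 nM.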

Compound 3, concentration lethal to 50% of the cells: 21500 nM
Compound 3: middle estimate off by 6.1-fold (0.79 log units), on the low side; measured number outside the range, above it.
By their numbers in this assay, from the lowest: compound 2; then compound 1; then compound 3.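

Trifluoromethyl and chloro are not interchangeable at this position, ortho to a chloro group: an 8.3-fold higher number from compound 2 to compound 3 (0.92 log units; beyond the scatter) in this assay, which means lower toxicity in this test. The ring with two chloro groups also gives a higher number than the ring with trifluoromethyl alone, with a 3.8-fold higher number from compound 1 to compound 3 (0.58 log units; beyond the scatter). On these data alone, whether a methyl, a methoxy or a nitrile here would behave more like chloro or like trifluoromethyl remains open. Nothing measured here explains the gap between these two groups.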